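This account rests on a few compounds, and the source may have more. Where it says the series, first, only, none or still open, it means among the compounds named here.

The measured compounds in an ADME assay on NCM460 cells (Homo sapiens) for cytotoxicity, read by MTT assay, with a stated time of 72 h; on this read-out higher numbers stand for weaker inhibition and lower numbers for stronger inhibition:

Compound 1, `CCOc1ccc(NC(=O)c2cccc(/C=C3\CC(=O)N(c4ccccc4)C3=O)c2)cc1` — gives > 100000 nM, which is a limit of the assay and not a number.
Compound 2, `COc1ccc(NC(=O)c2cccc(/C=C3\CC(=O)N(c4ccccc4)C3=O)c2)cc1` — gives > 100000 nM, again a limit of the assay.
Compound 3, `Cc1ccc(NC(=O)c2cccc(/C=C3\CC(=O)N(c4ccccc4)C3=O)c2)cc1C` — gives > 100000 nM, also a limit of the assay.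

All three values sit at the same limit, (the limit of > 100000 nM in this assay, at which 3 of the 3 values shown sit), so compound 3 cannot be placed above or below its neighbours; it shares the same unreadable position. The steps that touch the group on the amide-type nitrogen, a step that the two limits leave unreadable from compound 1 to compound 3 and a step that the two limits leave unreadable from compound 2 to compound 3, are therefore of unknown size, as is the step on the ether chain, a step that the two limits leave unreadable from compound 1 to compound 2.

The next compound is compound 4, `CCc1cccc(NC(=O)c2cccc(/C=C3\CC(=O)N(c4ccccc4)C3=O)c2)c1`. It differs from compound 3 by 3-ethylphenyl in place of 3,4-dimethylphenyl on an amide-type nitrogen. The same atoms remain, only arranged differently on the ring that hangs from the amide-type nitrogen. The two readable comparisons on that nitrogen, a step that the two limits leave unreadable from compound 1 to compound 3 and a step that the two limits leave unreadable from compound 2 to compound 3, show nothing beyond the limit. No direction can be read for the step from compound 3 to compound 4 in this assay.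

The expectation is that compound 4 behaves like its three neighbours, so its step is estimated as a step that the limit leaves unreadable from compound 3 to compound 4. Compound 4 is therefore estimated at 150000 nM, with a range from 60000 nM to 400000 nM, most likely reported again only as a limit.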

Compound 4, half-maximal inhibitory concentration: > 100000 nM
Compound 4 gave a limit, no number; the forecaster's own chance of this, stated with the estimate: 80%; the middle value is on the limit's open side.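

In this assay compound 4 gives > 100000 nM, which is a limit of the assay and not a number. The steps linking compound 4 to compound 1, compound 2 and compound 3 therefore cannot be read, because all four compounds share one limit: the limit of > 100000 nM in this assay, at which 4 of the 4 values shown sit.

The compounds shown leave open whether changing the group on the amide-type nitrogen alters this read-out at all.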